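The compounds below may be only part of what the source reports. "The series", "measured", "known", "first", "only" and "open" are said of these compounds alone.

Working notes on a small quinazoline-thioether set, all compounds carrying the same benzylthio arm with a trifluoromethyl group, and differing only in the methoxy pattern of the anilino ring, tested in a functional assay on MDA-MB-231 cells (Homo sapiens) for cytotoxicity, read by MTT assay, with a stated time of 72 h; on this read-out higher numbers stand for weaker inhibition and lower numbers for stronger inhibition.

Compound 1 `COc1ccccc1Nc1nc(SCc2ccc(C(F)(F)F)cc2)nc2ccccc12` in this assay gives > 50000 nM, which is a limit of the assay and not a number. Compound 2 `COc1ccc(Nc2nc(SCc3ccc(C(F)(F)F)cc3)nc3ccccc23)c(OC)c1` likewise gives > 50000 nM, again a limit. Among the measured compounds shown here, compound 3 `COc1ccc(Nc2nc(SCc3ccc(C(F)(F)F)cc3)nc3ccccc23)cc1OC` is the one member with a measured number, 18900 nM in this assay. The step of an at least 2.6-fold lower number from compound 1 to compound 3 (0.42 log units; beyond the scatter) and the step of an at least 2.6-fold lower number from compound 2 to compound 3 (0.42 log units; beyond the scatter) therefore both read as at least modest gains, with the actual size open because of the limit of > 50000 nM in this assay, at which 2 of the 3 values shown sit. The step that the two limits leave unreadable from compound 1 to compound 2 cannot be read at all because of the limit of > 50000 nM in this assay, at which 2 of the 3 values shown sit.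

The change from compound 1 to compound 2 is methoxy in place of hydrogen on an aromatic carbon. Compound 4 `COc1cc(Nc2nc(SCc3ccc(C(F)(F)F)cc3)nc3ccccc23)cc(OC)c1OC` carries the same kind of change relative to compound 3, (methoxy in place of hydrogen on an aromatic carbon), though the surroundings differ: in compound 2 the entering methoxy sits meta to a methoxy group and para to a large group, whereas in compound 4 it sits ortho to a methoxy group, meta to a large group and meta to a methoxy group. The two parent compounds themselves differ by 3,4-dimethoxyphenyl in place of 2-methoxyphenyl on a nitrogen on an aromatic ring.

For the measured compounds named here, for compound 4 the step of a 1.3-fold lower number from compound 3 to compound 4 (0.10 log units; within the scatter) is expected to be small, since the earlier occurrence of this change, a step that the two limits leave unreadable from compound 1 to compound 2, gives no usable size and the only anchor is compound 3 at 18900 nM. Compound 4 is accordingly estimated at 15000 nM in this assay, within 4000 nM to 50000 nM.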

Compound 4, half-maximal inhibitory concentration: > 50000 nM
Compound 4: no number, only a limit (the forecaster's own chance of this, stated with the estimate: 30%); at least 3.3-fold (0.52 log units) between middle value and limit.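

The one readable occurrence of methoxy in place of hydrogen on an aromatic carbon is an at least 2.6-fold higher number from compound 3 to compound 4 (0.42 log units; beyond the scatter), an at least modest weakening in this assay, with the true size open and with compound 4 holding a limit of the assay and not a number. This shows that, on the 3,4-dimethoxyphenyl parent, the entering methoxy, ortho to a methoxy group, meta to a large group and meta to a methoxy group, does not keep the measured level of compound 3. It does not show whether the change behaves alike on the 2-methoxyphenyl parent, since the occurrence from compound 1 to compound 2 cannot be read, and the two occurrences cannot be compared in size because so few values in the set are numbers: the limit of > 50000 nM in this assay, at which 3 of the 4 values shown sit.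

The compounds shown leave open whether a group other than methoxy on the anilino ring, such as an amine, a carboxylic acid or a longer alkoxy chain, would give a lower number than compound 3 in this assay. They also leave open what happens when the trifluoromethyl group on the benzylthio arm gives way to a nitrile or a carboxylic acid, with the methoxy pattern of compound 3 held fixed.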